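This account rests on a few compounds, and the source may have more. Where it says the series, first, only, none or still open, it means among the compounds named here.

Two compounds have been measured in a functional assay on DU-145 cells (Homo sapiens) for inhibition, read by MTT assay, with a stated time of 24 h; on this read-out lower numbers stand for stronger inhibition and higher numbers for weaker inhibition:

compound 1, `CCOC(=O)C1=Cc2ccccc2OC1(OCc1cn(CC(=O)NC2CCCCC2)nn1)C(F)(F)F`, gives 10200 nM;
compound 2, `Cc1ccc(-c2cc(COC3(C(F)(F)F)Oc4ccccc4C=C3C(=O)O)on2)cc1`, gives 41400 nM.

Of these two numbers, compound 1 holds the lower one, and the gap to compound 2 lies beyond the usual scatter of repeated measurements, so the difference between them is a real one. Among the measured compounds shown here, no single structural step links compound 1 and compound 2, so their values only show where each of them stands. Compound 3, `CCOC(=O)C1=Cc2ccccc2OC1(OCc1cn(-c2ccccc2)nn1)C(F)(F)F`, has not yet been measured. It arises from compound 1 by one change: phenyl in place of (cyclohexylcarbamoyl)methyl on an aromatic nitrogen. The rest of the shared core is kept unchanged. For the measured compounds named here, nothing measured so far shows what such a change on an aromatic nitrogen does in this assay, so the expectation rests on compound 1 alone and carries a wide uncertainty. The step of a 1.2-fold higher number from compound 1 to compound 3 (0.07 log units; within the scatter) is expected to stay within the usual scatter, in no particular direction. On that basis compound 3 is expected to give about 12000 nM, with a plausible range from 4000 nM to 40000 nM.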

Compound 3, half-maximal inhibitory concentration: > 150000 nM
Compound 3 gave a limit, no number (the forecaster's own chance of this, stated with the estimate: 15%); middle value at least 12-fold (1.09 log units) away from the limit.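

In this assay, compound 3 gives only a limit of the assay, not a number: the limit of > 150000 nM in this assay, at which 1 of the 3 values shown sits. Putting phenyl in place of (cyclohexylcarbamoyl)methyl on this aromatic nitrogen gives an at least 14-fold higher number from compound 1 to compound 3 (1.16 log units; beyond the scatter), a large loss of inhibition, so the group carried here has a strong bearing on the result while the rest of the shared core stays unchanged. Among the compounds shown here, the earlier compounds offered no step at this position, and this is the first direct sign that it is sensitive to change.

The compounds shown leave open which part of the departing group matters, since this one change removes the amide with its hydrogen-bond donor and acceptor, and also replaces a non-aromatic ring of carbon with an aromatic one. Going by these compounds, a cyclohexyl ring set directly on the nitrogen, or a (phenylcarbamoyl)methyl group, would pull these parts apart, and how far the loss really reaches also stays unknown, as the value for compound 3 is a limit.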